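The compounds below may be only part of what the source reports. "The series", "measured", "known", "first", "only" and "open" are said of these compounds alone.

Three compounds share one core and differ only at one end. In a functional assay on 786-0 cells (Homo sapiens) for inhibition, read by sulforhodamine B assay, with a stated time of 48 h, tested at 0.1 uM (a higher number here means a weaker effect of the compound at the concentration tested, a lower number a stronger effect), compound 1 `O=C(Nc1cccc(-n2cc(-c3ccncc3)c(-c3cc(O)cc(Cl)c3)n2)c1)Nc1ccc(Cl)c(C(F)(F)F)c1` gives 95%. Compound 2 `O=C(Nc1cccc(-n2cc(-c3ccncc3)c(-c3cc(O)cc(Cl)c3)n2)c1)Nc1ccc(Cl)c(Cl)c1` gives 90%, and compound 3 `COc1cc(Cl)cc(-c2nn(-c3cccc(NC(=O)Nc4cc(C(F)(F)F)cc(C(F)(F)F)c4)c3)cc2-c2ccncc2)c1` gives 92%. Compound 3 thus stands second highest of the three numbers, within the scatter of both compound 1 and compound 2. Compound 4 `COc1cc(Cl)cc(-c2nn(-c3cccc(NC(=O)Nc4cccc(C(F)(F)F)c4)c3)cc2-c2ccncc2)c1` differs from compound 3 in one place: hydrogen in place of trifluoromethyl on an aromatic carbon. Going by the values given here, the only measured step between neighbours, a number 5 percentage points lower from compound 1 to compound 2 (within the scatter), lay within the scatter, and no measured step removes a group outright. Since all three numbers sit close together, no step beyond the scatter is expected. Compound 4 is therefore estimated at 92%, between 82% and 100%. The expected step is no change at the digits printed from compound 3 to compound 4 (within the scatter).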

Compound 4, a percentage reported as activity, at one concentration (the size of the read-out at that concentration, not a potency): 99%
The estimate for compound 4 lay 7 percentage points below the measured number, and the stated range covers the measured number.
By their numbers in this assay, from the lowest: compounds 2, 3, 1 and 4 (each within the scatter of the next).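

With hydrogen in place of trifluoromethyl on this aromatic carbon, this assay gives a number 7 percentage points higher from compound 3 to compound 4 (within the scatter). This is the first step shown that takes a group away rather than swapping it for another, and even this loss stays inside the usual scatter. At this one concentration, the read-out therefore does not show that this trifluoromethyl group matters. From the compounds shown here alone, whether an amine or a carboxylic acid on the same carbon would give a step beyond the scatter remains open. Nothing shown bears on the reason for this step.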